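Compound 3 and a limit in rat microsomes

This account rests on a few compounds, and the source may have more. Where it says the series, first, only, none or still open, it means among the compounds named here.

- Compound 1 `Nc1nc(NCCNc2ncc(-c3ncc[nH]3)c(-c3ccccc3Cl)n2)ccc1[N+](=O)[O-]`: > 0.5 h, a limit
- Compound 2 `Nc1nc(NCCNc2ncc(-c3ncc[nH]3)c(-c3ccc(Cl)cc3F)n2)ccc1[N+](=O)[O-]`: > 0.5 h, a limit

In an ADME assay on microsomes from liver (Rattus norvegicus) for metabolic stability (a higher number here means that the compound lasts longer, a lower number that the compound disappears faster), compound 2 gives no number, only the limit > 0.5 h. Both measured compounds stand there: the limit of > 0.5 h in this assay, at which 2 of the 2 values shown sit. Compound 3 `Nc1nc(NCCNc2ncc(-c3ncc[nH]3)c(-c3cc(F)c(Cl)cc3F)n2)ccc1[N+](=O)[O-]` carries fluoro in place of hydrogen on an aromatic carbon, fluoro in place of hydrogen on an aromatic carbon, turning 4-chloro-2-fluorophenyl into 4-chloro-2,5-difluorophenyl. Among the measured compounds shown here, the one measured step is a step that the two limits leave unreadable from compound 1 to compound 2, so it offers no size to carry over. No change beyond the scatter is expected in this assay, in either direction. The step expected is a step that the limit leaves unreadable from compound 2 to compound 3. In this assay the estimated value for compound 3 is 0.7 h, with an expected range of 0.4 h to 1.3 h.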

Compound 3, half-life: > 0.5 h
Compound 3: a limit, no number; the forecaster's own chance of this, stated with the estimate: 80%; the middle value lies beyond the limit too.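

Compound 3 gives > 0.5 h, a limit and not a number, so no step among compound 1, compound 2 and compound 3 can be read in this assay: the limit of > 0.5 h in this assay, at which 3 of the 3 values shown sit.

The compounds shown leave open how long each of the three actually lasts, and whether the added fluoro changes that at all.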